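The source may hold more compounds than are shown below. What is called first, only, known or untested is meant among the compounds shown, and "the series" means these compounds.

Compound 1 `COc1cc(-c2nn(-c3cccc(NC(=O)c4ccc(Cl)c(C(F)(F)F)c4)c3)cc2-c2ccncc2)ccc1Cl`, compound 2 `O=C(Nc1cccc(-n2cc(-c3ccncc3)c(-c3ccc(Cl)c(O)c3)n2)c1)Nc1cc(C(F)(F)F)cc(C(F)(F)F)c1` and compound 3 `COc1cc(-c2nn(-c3cccc(NC(=O)c4ccccc4)c3)cc2-c2ccncc2)ccc1Cl` were measured. In a functional assay on SF-295 cells (Homo sapiens) for inhibition, read by sulforhodamine B assay, with a stated time of 48 h (on this read-out lower numbers stand for higher toxicity in this test and higher numbers for lower toxicity in this test), compound 2 gives 4390 nM. Compound 1 reaches only a limit of this assay, > 32500 nM. Compound 3 likewise reaches only a limit, > 100000 nM. Within the data shown here, compound 2 therefore stands as the single real number among the three. Among the measured compounds shown here, the step that the two limits leave unreadable from compound 1 to compound 3 has both ends at limits, so its size is not readable, and no measured step bears on the change considered here. Compound 4 `O=C(Nc1cccc(-n2cc(-c3ccncc3)c(-c3ccc(Cl)c(O)c3)n2)c1)Nc1cccc(C(F)(F)F)c1` differs from compound 2 by hydrogen in place of trifluoromethyl on an aromatic carbon. For the measured compounds named here, with no comparable measured step, only a modest shift toward lower toxicity is expected. Compound 4 is estimated at 7000 nM, within 2500 nM to 25000 nM. That estimate means an expected step of a 1.6-fold higher number from compound 2 to compound 4 (0.20 log units; within the scatter).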

Compound 4, concentration lethal to 50% of the cells: 29200 nM
Estimate against measurement, compound 4: 4.2-fold (0.62 log units) below, and the stated range ends below it.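

Hydrogen in place of trifluoromethyl on an aromatic carbon gives the first readable step among these compounds in this assay: a 6.7-fold higher number from compound 2 to compound 4 (0.82 log units; beyond the scatter). The higher number means lower toxicity in this test, so this trifluoromethyl group, meta to a second one, clearly counts toward the toxicity of compound 2. Nothing measured here explains the size of this step.

As far as these compounds go, whether a methyl group or a chlorine atom at this same carbon would keep that toxicity remains open, as does the effect of replacing the remaining trifluoromethyl group.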